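Swapping the Aniline Ring: Fluorine Out, Ethyl In

A few compounds are considered here, and "the series" means these few. Any claim that something is new, unique, unknown or untested is made for them only; others in the source may bear on it.

Compound 1 `COc1cc2ncnc(Nc3cccc(F)c3)c2cc1OCCCCC(=O)Nc1ccc(S(N)(=O)=O)cc1` was tested in a functional assay on NCI-H1975 cells (Homo sapiens) for antiproliferative activity, read by MTT assay, with a stated time of 72 h; a higher number here means a weaker inhibitor, a lower number a stronger inhibitor. In this assay compound 1 gives > 40000 nM, which is a limit of the assay rather than a number. Compound 2 `COc1cc2ncnc(Nc3ccc(F)cc3)c2cc1OCCCCC(=O)Nc1ccc(S(N)(=O)=O)cc1` gives > 40000 nM in this assay, again only a limit. For the measured compounds named here, compound 3 `COc1cc2ncnc(Nc3ccc(OC(F)(F)F)cc3)c2cc1OCCCCC(=O)Nc1ccc(S(N)(=O)=O)cc1` gives 8770 nM in this assay, the only measurable number of the three. Compound 1 therefore stands at the top edge of what the assay reports, sharing the limit of > 40000 nM in this assay, at which 2 of the 3 values shown sit, with compound 2.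

Compound 4 `CCc1ccc(Nc2ncnc3cc(OC)c(OCCCCC(=O)Nc4ccc(S(N)(=O)=O)cc4)cc23)cc1` differs from compound 1 in one place: 4-ethylphenyl in place of 3-fluorophenyl on a nitrogen on an aromatic ring. Going by the values given here, three measured steps concern the same nitrogen. The step that the two limits leave unreadable from compound 1 to compound 2 cannot be sized, since both ends are limits. The step of an at least 4.5-fold lower number from compound 1 to compound 3 (0.65 log units; beyond the scatter) and the step of an at least 4.5-fold lower number from compound 2 to compound 3 (0.65 log units; beyond the scatter) both show that a 4-(trifluoromethoxy)phenyl gave a clearly lower number than either fluorophenyl. The 4-ethylphenyl of compound 4 is none of these groups, so only a cautious expectation is possible: a lowering in this assay, probably smaller than that seen for compound 3, with a real chance that only a limit is returned again. Compound 4 is expected to give 15000 nM, within 4000 nM to 45000 nM. The expected step is an at least 2.6-fold lower number from compound 1 to compound 4 (0.42 log units; beyond the scatter).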

Compound 4, half-maximal inhibitory concentration: 10300 nM
For compound 4 the middle estimate is 1.5-fold (0.16 log units) above the measured one, and the stated range covers the measured number.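

Replacing a fluorophenyl with the 4-ethylphenyl brings a clear lowering in this assay, with an at least 3.8-fold lower number from compound 1 to compound 4 (0.58 log units; beyond the scatter) and, for ethyl in place of fluoro on the same aromatic carbon, an at least 3.8-fold lower number from compound 2 to compound 4 (0.58 log units; beyond the scatter). The new information comes from the comparison with the trifluoromethoxy group, which gives a 1.2-fold higher number from compound 3 to compound 4 (0.07 log units; within the scatter); an ethyl group, made of carbon and hydrogen alone, therefore matches the trifluoromethoxy group here, and a measurable number at this position does not depend on that group's fluorine or oxygen atoms. Compound 1 and compound 2 each still give only a limit, so these two steps have a minimum size but no exact one: the limit of > 40000 nM in this assay, at which 2 of the 4 values shown sit.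

The compounds shown leave open whether a methoxy group, a chlorine atom or a longer chain such as propyl in place of the ethyl would lower the number further or lose the gain. For the compounds shown here, they also leave open whether the ethyl or trifluoromethoxy group needs to sit where it does on the aniline ring, since the only pair that differs in ring position, compound 1 and compound 2, cannot be read.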